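Working notes on the step from compound 3 to compound 4

This account rests on a few compounds, and the source may have more. Where it says the series, first, only, none or still open, it means among the compounds named here.

Compound 3, `COc1ccc(C2=NN(c3ccc(S(N)(=O)=O)cc3)C(c3cn(-c4ccccc4)nc3-c3ccc(C)cc3)C2)cc1`, was tested in an ADME assay on Vero cells (Chlorocebus sabaeus) for cytotoxicity, read by MTT assay, with a stated time of 72 h; on this read-out lower numbers stand for higher toxicity in this test and higher numbers for lower toxicity in this test. In this assay compound 3 gives > 36600 nM, which is a limit of the assay and not a number, as the limit of > 36600 nM in this assay, at which 1 of the 3 values shown sits, records. Compound 1, `Cc1ccc(C2=NN(c3ccc(S(N)(=O)=O)cc3)C(c3cn(-c4ccccc4)nc3-c3ccc(C)cc3)C2)cc1`, gives > 41400 nM in this assay, again a limit, as the limit of > 41400 nM in this assay, at which 1 of the 3 values shown sits, records. Compound 2, `Cc1ccc(-c2nn(-c3ccccc3)cc2C2CC(c3ccccc3)=NN2c2ccc(S(N)(=O)=O)cc2)cc1`, gives > 161000 nM in this assay, once more a limit, as the limit of > 161000 nM in this assay, at which 1 of the 3 values shown sits, records. Because all three values sit at limits, the steps a step that the two limits leave unreadable from compound 1 to compound 2, a step that the two limits leave unreadable from compound 1 to compound 3 and a step that the two limits leave unreadable from compound 2 to compound 3 cannot be sized; compound 3 therefore stands at a limit alongside the other two, with no readable order among them.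

Compound 4, `COc1cccc(C2=NN(c3ccc(S(N)(=O)=O)cc3)C(c3cn(-c4ccccc4)nc3-c3ccc(C)cc3)C2)c1OC`, differs from compound 3 by 2,3-dimethoxyphenyl in place of 4-methoxyphenyl on a carbon with a double bond to nitrogen. The steps that touch the same aryl group, from compound 1 to compound 3 and from compound 2 to compound 3, bear on this change, but both are unreadable, so no size or direction of step in this assay can be taken from them. The expectation for compound 4 is a further limit rather than a measured value, so the step that the limit leaves unreadable from compound 3 to compound 4 is estimated to lie within the scatter. The estimate for compound 4 in this assay is 50000 nM, with a range from 15000 nM to 200000 nM.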

Compound 4, half-maximal cytotoxic concentration: > 57300 nM
Compound 4 ended at the assay's limit (the forecaster's own chance of this, stated with the estimate: 80%); at least 1.1-fold (0.05 log units) between middle value and limit.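

In this assay compound 4 gives > 57300 nM, which is a limit of the assay and not a number. For the compounds shown here, all four values are limits, so no step from compound 1, compound 2 or compound 3 to compound 4 can be read. The compounds shown leave open whether changing the aryl group on the carbon with a double bond to nitrogen alters cytotoxicity at all.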